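A Carbamoyl Group on the Sulfur-Bound Chain

The source may report more compounds than this note shows. Statements on the series, on what has been measured and on what is new or still open speak of the compounds shown alone.

Of the compounds shown here, two sharing one core have been measured in a functional assay on HT cells (Homo sapiens) for antiproliferative activity, read by fluorescence, with a stated time of 72 h; a higher number here means a weaker inhibitor of growth, a lower number a stronger inhibitor of growth. Compound 1 (`CC(C)c1n[nH]c2c(NCc3ccc(-c4ccccn4)cc3)nc(SCC3CNC(=O)O3)nc12`) gives 80 nM. Compound 2 (`CC(C)c1n[nH]c2c(NCc3ccc(-c4ccccn4)cc3)nc(SCC(C)(C)N)nc12`) gives 85 nM. For the measured compounds named here, compound 2 therefore stands level with compound 1, the only other measured compound, and nothing separates the two beyond the scatter.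

Compound 3 (`CC(C)c1n[nH]c2c(NCc3ccc(-c4ccccn4)cc3)nc(SCC(N)=O)nc12`) carries carbamoyl in place of 1-amino-1-methylethyl on a saturated chain carbon bound to a sulfur. Going by the values given here, one measured step bears on this change, a 1.1-fold higher number from compound 1 to compound 2 (0.03 log units; within the scatter). That step exchanged 2-oxo-1,3-oxazolidin-5-yl for 1-amino-1-methylethyl at the same place, and the two values stayed within the scatter. Among the compounds with values here, this is thin support, since it is a single step and no measured compound yet carries carbamoyl there. No step beyond the scatter is therefore expected, and no direction can be favoured. The estimate amounts to an expected 1.1-fold higher number from compound 2 to compound 3 (0.02 log units; within the scatter). For compound 3, the expected value in this assay is 90 nM, with an estimated range of 35 nM to 230 nM.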

Compound 3, concentration for 50% growth inhibition: 192 nM
The estimate for compound 3 lay 2.1-fold (0.33 log units) below the measured number; low and high end bracket the measured number.
By their numbers in this assay, from the lowest: compounds 1 and 2 (each within the scatter of the next); then compound 3.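

The place on a saturated chain carbon bound to a sulfur proved not to be indifferent in this assay: carbamoyl in place of 1-amino-1-methylethyl gave a 2.3-fold higher number from compound 2 to compound 3 (0.35 log units; beyond the scatter), a modest step but one beyond the scatter. The same holds against the ring-bearing group, since carbamoyl in place of 2-oxo-1,3-oxazolidin-5-yl gave a 2.4-fold higher number from compound 1 to compound 3 (0.38 log units; beyond the scatter), so that carbamoyl sets compound 3 apart as the weakest inhibitor of growth of the three, while the two groups it replaced remain level with each other. Nothing available here explains why this group departs from the other two.

The compounds shown leave open whether the loss follows the carbamoyl group itself or the whole change from (2-amino-2-methylpropyl)sulfanyl to (carbamoylmethyl)sulfanyl, as a longer chain ending in the same carbamoyl would help to separate these two readings. They also leave open how a carboxylic acid or an unbranched primary amine at the end of this chain would compare with the three groups seen so far.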